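Adding a 4-Acetoxybenzyl Group to Compound 3

The source may report more compounds than this note shows. Statements on the series, on what has been measured and on what is new or still open speak of the compounds shown alone.

Compound 3 `COc1ccc(C(=O)NO)cc1S(=O)(=O)Nc1ccc2c(c1)cc(C)c(=O)n2C` gives 10% in a functional assay on HL-60 cells (Homo sapiens) for antiproliferative activity, tested at 20 uM (a lower number here means a weaker effect, a higher number a stronger effect of the compound at the concentration tested), the lowest of the three measured numbers. Compound 1 `Cc1cc2cc(NS(=O)(=O)c3cc(C(=O)NO)ccc3Cl)ccc2n(C)c1=O` gives 32%; the change a number 22 percentage points lower from compound 1 to compound 3 (beyond the scatter) lies beyond the scatter. Compound 2 `COc1ccc(C(=O)NOCc2ccccc2)cc1S(=O)(=O)Nc1ccc2c(c1)cc(C)c(=O)n2C` gives 13%, and the change a number 3 percentage points lower from compound 2 to compound 3 (within the scatter) lies within the scatter.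

Compound 4 `COc1ccc(C(=O)NOCc2ccc(OC(C)=O)cc2)cc1S(=O)(=O)Nc1ccc2c(c1)cc(C)c(=O)n2C` differs from compound 3 by 4-acetoxybenzyl in place of hydrogen on an oxygen. The step from compound 2 to compound 3 bears on this change, since it also concerns a benzyl-type group on that same oxygen, and it was within the scatter. Therefore no step beyond the scatter is expected, a number 3 percentage points higher from compound 3 to compound 4 (within the scatter). Compound 4 is estimated at 13%, within a range from 3% to 25%.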

Compound 4, a percentage reported as inhibition, at one concentration (the size of the read-out at that concentration, not a potency): 0%
Beside the measured number, compound 4's estimate is 13 percentage points above it, and the stated range ends above it.
By their numbers in this assay, from the lowest: compounds 4, 3 and 2 (each within the scatter of the next, the first and the last beyond it); then compound 1.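

In this assay, the step to 4-acetoxybenzyl on this oxygen, a number 10 percentage points lower from compound 3 to compound 4 (within the scatter), adds nothing that can be told from the scatter, so this large group alone does not shift the read-out measurably. Going by these compounds alone, the acetoxy group on the aromatic ring of the benzyl does show an effect, since adding it gives a number 13 percentage points lower from compound 2 to compound 4 (beyond the scatter), the first change at this end of the molecule to exceed the scatter. No measurement shown explains this drop. Going by these compounds, whether it is specific to acetoxy remains open, as a hydroxy or an amine at that ring carbon could show. So does whether the same benzyl groups would act alike on the chloro compound 1.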